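Compound 2: replacing hydroxy with hydrogen

This account rests on a few compounds, and the source may have more. Where it says the series, first, only, none or still open, it means among the compounds named here.

Of the compounds shown here, two have numbers so far in a functional assay on PANC-1 cells (Homo sapiens) for cytotoxicity, read by fluorescence, with a stated time of 24 h; a lower number here means a stronger inhibitor, a higher number a weaker inhibitor. Compound 1 `COC(C)(C)CCCC1(C)CCc2c(CCC(=O)c3ccc(O)cc3O)ccc(O)c2O1` gives 48300 nM, and compound 2 `C=C1C(=O)O[C@H]2/C=C(\C)C[C@@H]3C=C(C/C=C/[C@@](C)(OO)CC[C@H]12)C(=O)O3` gives 17900 nM. Compound 2 therefore holds the lower of the two numbers, and the gap between them lies beyond the usual scatter. The two structures differ in many places, so this gap says nothing about any single change.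

Compound 3 `C=C1C(=O)O[C@H]2/C=C(\C)C[C@@H]3C=C(C/C=C/[C@@](C)(O)CC[C@H]12)C(=O)O3` is not yet measured. It keeps the structure of compound 2 apart from one change: hydrogen in place of hydroxy on an oxygen on a saturated carbon, so that hydroxyoxy becomes hydroxy. For the measured compounds named here, the series holds no measured pair with this change, so the expectation rests on compound 2 at 17900 nM and carries wide uncertainty. A shift beyond the scatter is not expected, only a slight lean towards a higher number in this assay. The expected step is a 1.5-fold higher number from compound 2 to compound 3 (0.16 log units; within the scatter). For compound 3 the estimated value is 26000 nM, with an expected range from 10000 nM to 60000 nM.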

Compound 3, half-maximal inhibitory concentration: 46900 nM
The estimate for compound 3 lay 1.8-fold (0.26 log units) below the measured number; low and high end bracket the measured number.
By their numbers in this assay, from the lowest: compound 2; then compounds 3 and 1 (each within the scatter of the next).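

In this assay, for the compounds shown here, compounds 2 and 3 form the first measured pair that differs in one place, and the change from hydroxyoxy to hydroxy gives a 2.6-fold higher number from compound 2 to compound 3 (0.42 log units; beyond the scatter). The earlier gap between compound 1 and compound 2 could not be assigned to any single change, whereas this pair shows that the position is not silent: removing the outer hydroxy alone moves the number beyond the scatter, towards a weaker inhibitor, though the step remains modest. No supporting measurement is available to explain this step, so it stands as an observation on one pair.

The compounds shown leave open whether the step is specific to hydroxyoxy or would also appear with other groups at this place, such as an amine, a fluorine or an acetate ester. Going by these compounds alone, they also leave open whether the same change would shift the number by a similar amount on a different core, since this single pair on the core of compound 2 is the only reading of it.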